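A few compounds are considered here, and "the series" means these few. Any claim that something is new, unique, unknown or untested is made for them only; others in the source may bear on it.

Measured so far:
Compound 1 `Cn1c(-c2ccc(NC(=O)CN3CCCC3)cc2)nc2cc(C(F)(F)F)ccc21` gives in an ADME assay on Vero cells (Chlorocebus sabaeus) for cytotoxicity (a lower number here means that less compound is tolerated, a higher number that more compound is tolerated), a value of > 100000 nM, which is a limit of the assay.
Compound 2 `CCN(CC)CC(=O)Nc1ccc(-c2nc3cc(C(F)(F)F)ccc3n2C)cc1` gives in this assay a value of 90000 nM.
Compound 3 `CCC(=O)Nc1ccc(-c2nc3cc(C(F)(F)F)ccc3n2C)cc1` gives in this assay a value of > 100000 nM, which is again a limit of the assay.

Compound 3 therefore stands at the limit where most of these values sit (the limit of > 100000 nM in this assay, at which 2 of the 3 values shown sit); for it only a limit is known, not a number. Compound 4 `Cn1c(-c2ccc(NC(=O)CN3CCN(c4ccccc4)CC3)cc2)nc2cc(C(F)(F)F)ccc21` differs from it in one place: 4-phenylpiperazin-1-yl in place of methyl on a saturated chain carbon bound to a carbonyl carbon. Going by the values given here, two measured steps touch the same place and end in compound 3. The first is an at least 1.1-fold higher number from compound 2 to compound 3 (0.04 log units; that floor lies within the scatter), a step whose floor lies within the scatter. The second is a step that the two limits leave unreadable from compound 1 to compound 3; both of its ends are limits of the assay. The remaining step, an at least 1.1-fold lower number from compound 1 to compound 2 (0.04 log units; that floor lies within the scatter), also stays within the scatter. None of the three changes at this place moves the numbers visibly away from the limit, so for the larger 4-phenylpiperazin-1-yl no step beyond the scatter is expected in this assay, in either direction. Compound 4 is expected to give 80000 nM, within a range from 30000 nM to 100000 nM. This amounts to an expected step of an at least 1.2-fold lower number from compound 3 to compound 4 (0.09 log units; that floor lies within the scatter), with a fair chance that only a limit is reported.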

Compound 4, half-maximal cytotoxic concentration: 30000 nM
Beside the measured number, compound 4's estimate is 2.7-fold (0.43 log units) above it, and the stated range covers the measured number.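

In this assay, the saturated chain carbon bound to a carbonyl carbon now shows a change that goes beyond the scatter: 4-phenylpiperazin-1-yl in place of methyl gives an at least 3.3-fold lower number from compound 3 to compound 4 (0.52 log units; beyond the scatter). The same group gives a 3.0-fold lower number from compound 2 to compound 4 (0.48 log units; beyond the scatter) in place of diethylamino and an at least 3.3-fold lower number from compound 1 to compound 4 (0.52 log units; beyond the scatter) in place of pyrrolidin-1-yl, so a place that had shown no visible movement among methyl, diethylamino and pyrrolidin-1-yl does respond in this assay. Compound 4 is the only one of the four whose steps to all the others lie beyond the scatter, making it the least tolerated of them, though two of those steps are floors with one end on a limit of the assay: the limit of > 100000 nM in this assay, at which 2 of the 4 values shown sit.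

The compounds shown leave open whether the step belongs to the piperazine ring or to the phenyl ring, which enter together, and a 4-methylpiperazin-1-yl or a 4-phenylpiperidin-1-yl at the same place would separate the two. They also leave open whether another group in place of the phenyl ring, such as a pyridin-2-yl or a 4-fluorophenyl, would give a step of similar size.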